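From 3-fluorophenyl to phenethyl on a sulfur

The source may report more compounds than this note shows. Statements on the series, on what has been measured and on what is new or still open speak of the compounds shown alone.

Within the data shown here, in a functional assay on HCT-116 cells (Homo sapiens) for inhibition, read by CCK-8 assay, with a stated time of 72 h, tested at 8 uM (a lower number here means less inhibition of growth, a higher number more inhibition of growth at the concentration tested), compound 1 (`Nc1ccccc1NC(=O)c1ccc(CSc2cccc(F)c2)cc1`) gives 81.4% and stands highest of the two numbers so far. Compound 2 (`Nc1ccccc1NC(=O)/C=C/c1ccc(CSc2ccc(F)cc2)cc1`) gives 20.2% and lies lower, with a gap beyond the usual scatter. These two compounds differ in more than one place, so their gap cannot be assigned to any single change.

Compound 3 (`Nc1ccccc1NC(=O)c1ccc(CSCCc2ccccc2)cc1`) carries phenethyl in place of 3-fluorophenyl on a sulfur. The place of change is a sulfur whose other neighbour is a saturated chain carbon. Among the measured compounds shown here, no measured pair isolates a change of this kind, so the expectation rests on thin ground. Compound 1 at 81.4% leaves limited room upward, so a moderate fall in this assay is expected, and a result within the scatter would not be surprising. The expected size of the change is modest (a number 16.4 percentage points lower from compound 1 to compound 3 (beyond the scatter)). In this assay compound 3 is estimated at 65% (expected range 38% to 86%).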

Compound 3, percent growth inhibition at one concentration: 81.3%
The estimate for compound 3 lay 16.3 percentage points below the measured number; measured number inside the range.
By their numbers in this assay, from the lowest: compound 2; then compounds 3 and 1 (each within the scatter of the next).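

On the sulfur whose other neighbour is a saturated chain carbon, phenethyl in place of 3-fluorophenyl is tolerated in this assay: the step is a number 0.1 percentage points lower from compound 1 to compound 3 (within the scatter), and the two compounds read alike at the concentration tested. The position therefore accepts a group without fluorine and with 8 heavy atoms rather than 7, and the aromatic ring may sit on a chain instead of directly on the sulfur, at least for these two groups. No available data explain why the two groups read alike.

The compounds shown leave open whether this position needs an aromatic ring at all, as a plain alkyl chain would test, and whether it accepts an amine or a carboxylic acid at the end of the chain. A single concentration also cannot show whether compound 1 and compound 3 would separate at lower doses, and compound 2 at 20.2% differs from compound 1 in more than one place, so that gap still cannot be read as a step.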